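Cyclohexyl to Phenyl on the Amide Nitrogen

A few compounds are considered here, and "the series" means these few. Any claim that something is new, unique, unknown or untested is made for them only; others in the source may bear on it.

Compound 1 `O=C(O)CCc1cccc2c1B(O)OC2` and compound 2 `O=C(CCc1cccc2c1B(O)OC2)NC1CCCCC1` share one core. In an ADME assay on WI-38 cells (Homo sapiens) for cytotoxicity, read by MTT assay, with a stated time of 72 h (a higher number here means a weaker inhibitor, a lower number a stronger inhibitor), compound 1 gives only a limit, > 100000 nM. Compound 2 also reaches only a limit in this assay, namely > 100000 nM. The step that the two limits leave unreadable from compound 1 to compound 2 is therefore unreadable, since (the limit of > 100000 nM in this assay, at which 2 of the 2 values shown sit). Compound 3 `O=C(CCc1cccc2c1B(O)OC2)Nc1ccccc1` differs from compound 2 by phenyl in place of cyclohexyl on an amide-type nitrogen. Among the compounds with values here, no measured step bears on this change, as both values shown are limits, so the expected step is a step that the limit leaves unreadable from compound 2 to compound 3, with no change beyond the scatter foreseen. Compound 3 is estimated at 150000 nM in this assay, with a range from 40000 nM to 600000 nM.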

Compound 3, half-maximal inhibitory concentration: 30000 nM
Beside the measured number, compound 3's estimate is 5.0-fold (0.70 log units) above it, outside the stated range (below it).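

In this assay, within the data shown here, the group on the amide-type nitrogen proves able to move the number: phenyl in place of cyclohexyl gives an at least 3.3-fold lower number from compound 2 to compound 3 (0.52 log units; beyond the scatter), the first readable step. Anilino in place of hydroxy on a carbonyl carbon likewise gives an at least 3.3-fold lower number from compound 1 to compound 3 (0.52 log units; beyond the scatter). Both sizes are only lower bounds, since each step starts from a limit: the limit of > 100000 nM in this assay, at which 2 of the 3 values shown sit.

The compounds shown leave open whether benzyl on that nitrogen would give a number like that of phenyl. They also leave open whether a chlorine on the phenyl ring or a longer chain to the carbonyl would shift it further.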